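The source may report more compounds than this note shows. Statements on the series, on what has been measured and on what is new or still open speak of the compounds shown alone.

Measured so far in a functional assay on DLD-1 cells (Homo sapiens) for antiproliferative activity, read by CellTiter-Glo, with a stated time of 72 h; a higher number here means a weaker inhibitor, a lower number a stronger inhibitor:
Compound 1, `CC1CCN(C2CCN(S(=O)(=O)c3ccc(C#N)cc3)CC2)CC1`, gives 2800 nM.
Compound 2, `CC1CCN(C2CCN(S(=O)(=O)c3cccnc3)CC2)CC1`, gives 2400 nM.
Compound 3, `COc1ccccc1-c1ccc(S(=O)(=O)N2CCC(N3CCC(C)CC3)CC2)cc1`, gives 26 nM.

Compound 3 stands with the lowest number of the three in this assay; the other two lie far above it, compound 1 with 2800 nM and compound 2 with 2400 nM. The step of a 1.2-fold lower number from compound 1 to compound 2 (0.07 log units; within the scatter) shows that swapping the aryl group on the sulfonyl sulfur for a pyridin-3-yl changes little, whereas a 110-fold lower number from compound 1 to compound 3 (2.03 log units; beyond the scatter) shows that the 2-methoxyphenyl group brings the large gain.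

Compound 4, `CC1CCN(C2CCN(S(=O)(=O)c3ccc(-c4ccccc4F)cc3)CC2)CC1`, differs from compound 3 by fluoro in place of methoxy on an aromatic carbon. Among the compounds with values here, no measured pair bears directly on this swap; the only bearing step, a 110-fold lower number from compound 1 to compound 3 (2.03 log units; beyond the scatter), concerns the arrival of the whole 2-methoxyphenyl group, which compound 4 keeps as a 2-fluorophenyl. The large gain is therefore expected to be retained, and the step of a 1.5-fold higher number from compound 3 to compound 4 (0.19 log units; within the scatter) is expected to fall within or near the scatter. Compound 4 is estimated at 40 nM, within the range 15 nM to 110 nM.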

Compound 4, half-maximal inhibitory concentration: 5 nM
The estimate for compound 4 lay 8.0-fold (0.90 log units) above the measured number; the measured number lies below the stated range.
By their numbers in this assay, from the lowest: compound 4; then compound 3; then compounds 2 and 1 (each within the scatter of the next).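

In this assay the group on this aromatic carbon, ortho to a large group, matters beyond the presence of the added ring: a 5.2-fold lower number from compound 3 to compound 4 (0.72 log units; beyond the scatter) comes with fluoro in place of methoxy, a step that is modest but real. Measured against cyano, the 2-fluorophenyl group gives a 560-fold lower number from compound 1 to compound 4 (2.75 log units; beyond the scatter) and so the large gain seen with the 2-methoxyphenyl group does not depend on the methoxy or its hydrogen-bond acceptor. Nothing at hand accounts for the lower number with fluoro.

The compounds shown leave open how a chloro, methyl or hydroxy group would read at this place. They also leave open whether the advantage of fluoro over methoxy would hold with an amine or a carboxylic acid carried elsewhere on the shared core.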